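Adding a methyl to the hydroxy of compound 1

The compounds below may be only part of what the source reports. "The series", "measured", "known", "first", "only" and "open" are said of these compounds alone.

Values in a functional assay on MCF7 cells (Homo sapiens) for inhibition, read by MTT assay, with a stated time of 72 h; on this read-out lower numbers stand for stronger inhibition and higher numbers for weaker inhibition:
- compound 1 `CO[C@@H]1[C@H]2OC(=O)C[C@H]2O[C@@H]1[C@@H](O)c1ccccc1`: 12700 nM
- compound 2 `CO[C@@H]1[C@H]2OC(=O)C[C@H]2O[C@@H]1C(O)(c1ccccc1)c1ccccc1`: 11400 nM
- compound 3 `CO[C@@H]1[C@H]2OC(=O)C[C@H]2O[C@@H]1[C@H](O)c1ccccc1`: 4040 nM

Compound 1 shares the high end of these numbers with compound 2, and the two lie within the usual scatter of each other. Compound 4 `CO[C@@H]1[C@H]2OC(=O)C[C@H]2O[C@@H]1[C@@H](OC)c1ccccc1` keeps the core of compound 1 and makes one change, methyl in place of hydrogen on an oxygen on a saturated carbon: hydroxy to methoxy. Among the compounds with values here, no measured compound carries this methyl, so no step shows its effect directly. The closest evidence is a 3.1-fold lower number from compound 1 to compound 3 (0.50 log units; beyond the scatter), and that comes with the fact that compounds 1 and 3 differ only in the configuration as drawn. The carbon holding the hydroxy therefore matters to some degree, but this step gives no direction for the new change. Going by that modest step, the expectation in this assay is a shift no larger than it, most likely none beyond the scatter. The expected change is a 1.2-fold lower number from compound 1 to compound 4 (0.06 log units; within the scatter). For compound 4 the estimated value is 11000 nM, with an expected range of 4000 nM to 30000 nM.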

Compound 4, half-maximal inhibitory concentration: > 100000 nM
Compound 4 gave a limit, no number; the forecaster's own chance of this, stated with the estimate: 10%; middle value at least 9.0-fold (0.95 log units) from the limit.
By their numbers in this assay, from the lowest: compound 3; then compounds 2 and 1 (each within the scatter of the next). At a limit, above all of these: compound 4.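

The earlier compounds shown here spoke to this position only through its configuration: the fact that compounds 1 and 3 differ only in the configuration as drawn. Compound 4 adds that the group on this oxygen counts as well, since hydroxy to methoxy gives an at least 7.8-fold higher number from compound 1 to compound 4 (0.89 log units; beyond the scatter) in this assay. The value of compound 4, > 100000 nM, is a limit of the assay and not a number.

On these data alone, what stays open is whether the hydrogen on this oxygen is what matters, or whether the added methyl is what does not fit, and an amine in place of the hydroxy, or an acetyl group on the oxygen, would help to separate the two. As far as these compounds go, it is also open whether the same methyl would have a similar effect on compound 3, the compound with the other configuration at this carbon.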